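This account rests on a few compounds, and the source may have more. Where it says the series, first, only, none or still open, it means among the compounds named here.

Working notes on the series.

The shared core is that of compound 1 `CC1=CC[C@@H]([C@@](C)(O)CCCC(C)(C)NC(=S)NN)CC1`, which has only a free nitrogen on the amide-type nitrogen. In a functional assay on OVCAR-3 cells (Homo sapiens) for cytotoxicity, read by sulforhodamine B assay (on this read-out lower numbers stand for higher toxicity in this test and higher numbers for lower toxicity in this test), compound 1 gives a limit, > 100000 nM, and no number. Compound 2 `CC1=CC[C@@H]([C@@](C)(O)CCCC(C)(C)NC(=S)N/N=C\c2ccc(C)cc2)CC1` adds a group of 9 heavy atoms on that nitrogen; in this assay compound 2 gives 45300 nM. Compound 3 `CC1=CC[C@@H]([C@@](C)(O)CCCC(C)(C)NC(=S)N/N=C\c2ccc(O)cc2)CC1` differs from compound 2 by hydroxy in place of methyl on an aromatic carbon; in this assay compound 3 gives 54400 nM. Compound 3 and compound 2 sit close together, the gap being a 1.2-fold higher number from compound 2 to compound 3 (0.08 log units; within the scatter). The steps from the free nitrogen to the substituted compounds read an at least 2.2-fold lower number from compound 1 to compound 2 (0.34 log units; beyond the scatter) and an at least 1.8-fold lower number from compound 1 to compound 3 (0.26 log units; that floor lies within the scatter), both resting on the limit (the limit of > 100000 nM in this assay, at which 1 of the 3 values shown sits).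

Compound 4 `CC1=CC[C@@H]([C@@](C)(O)CCCC(C)(C)NC(=S)N/N=C(/C)c2ccccc2)CC1` is the next step: a group of 9 heavy atoms (8 carbon, 1 nitrogen; one six-membered aromatic ring of carbon only) in place of a group of 9 heavy atoms (7 carbon, 1 nitrogen, 1 oxygen; one six-membered aromatic ring of carbon only), on an amide-type nitrogen. Among the compounds with values here, no measured step covers this exchange. What bears on it is that the two substituted compounds differ only by a 1.2-fold higher number from compound 2 to compound 3 (0.08 log units; within the scatter), and that the substituents themselves gave at most an at least 2.2-fold lower number from compound 1 to compound 2 (0.34 log units; beyond the scatter) against the free nitrogen. A step within the scatter is therefore expected for compound 4, a 1.2-fold lower number from compound 3 to compound 4 (0.08 log units; within the scatter). Compound 4 is estimated at 45000 nM, in the range 20000 nM to 110000 nM.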

Compound 4, concentration lethal to 50% of the cells: > 100000 nM
Compound 4 gave a limit, no number; the forecaster's own chance of this, stated with the estimate: 20%; middle value at least 2.2-fold (0.34 log units) away from the limit.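

Compound 4 shows that this amide-type nitrogen, whose other neighbour is the thiocarbonyl carbon, does not accept every aromatic group of this size alike: with the count of 9 heavy atoms unchanged, the exchange gives an at least 2.2-fold higher number from compound 2 to compound 4 (0.34 log units; beyond the scatter). Within the data shown here, compound 2 and compound 3 had stayed within the scatter of each other, so the earlier compounds gave no sign of such a step, although the comparison with compound 3 is less firm, at an at least 1.8-fold higher number from compound 3 to compound 4 (0.26 log units; that floor lies within the scatter). Compound 4 gives only a limit in this assay, > 100000 nM, and not a number, so the step between it and the free nitrogen of compound 1 cannot be read: the limit of > 100000 nM in this assay, at which 2 of the 4 values shown sit.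

The compounds shown leave open how far compound 4 lies past that limit, and which feature of the entering group carries the step, as the groups of compound 2 and compound 4 differ in more than one feature. Also open, as far as these compounds go, is whether an amine or a carboxylic acid on the aromatic ring, or a longer chain in the group on this nitrogen, would give a number or another limit.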